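The compounds below may be only part of what the source reports. "The series", "measured", "known", "first", "only" and "open" are said of these compounds alone.

Compound 1, `COc1cc2c(Oc3ccc(NC(=O)c4nn(-c5ccccc5C)c(=O)cc4C)cc3F)ccnc2cc1OCCCN1CCN(C)CC1`: 1630 nM in a functional assay on MKN-45 cells (Homo sapiens) for inhibition, read by MTT assay, with a stated time of 72 h; on this read-out higher numbers stand for weaker inhibition and lower numbers for stronger inhibition.
Compound 2, `COc1cc2c(Oc3ccc(NC(=O)c4nn(-c5ccccc5C(F)(F)F)c(=O)cc4C)cc3F)ccnc2cc1OCCCN1CCCCC1`: 90 nM in this assay.
Compound 3, `COc1cc2c(Oc3ccc(NC(=O)c4nn(-c5ccccc5C(F)(F)F)c(=O)cc4C)cc3F)ccnc2cc1OCCCN1CCN(C)CC1`: 40 nM in this assay.

Compound 3 stands at the lowest number of the three. The nearest is compound 2, as a 2.3-fold lower number from compound 2 to compound 3 (0.35 log units; beyond the scatter) shows; the furthest is compound 1, as a 41-fold lower number from compound 1 to compound 3 (1.61 log units; beyond the scatter) shows. Compound 4, `COc1cc2c(Oc3ccc(NC(=O)c4nn(-c5ccccc5OC(F)(F)F)c(=O)cc4C)cc3F)ccnc2cc1OCCCN1CCN(C)CC1`, differs from compound 3 by trifluoromethoxy in place of trifluoromethyl on an aromatic carbon. Among the compounds with values here, no measured step swaps this same group, so there is no direct guide. Within the data shown here, the one step at this position, a 41-fold lower number from compound 1 to compound 3 (1.61 log units; beyond the scatter), concerns a different exchange and shows only that this place can matter a great deal. With both groups sharing three fluorines, compound 4 is expected to give 60 nM in this assay, between 20 nM and 200 nM. Against compound 3 this means an expected 1.5-fold higher number from compound 3 to compound 4 (0.18 log units; within the scatter).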

Compound 4, half-maximal inhibitory concentration: 100 nM
For compound 4 the middle estimate is 1.7-fold (0.22 log units) below the measured one; measured number inside the range.
By their numbers in this assay, from the lowest: compound 3; then compounds 2 and 4 (each within the scatter of the next); then compound 1.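

In this assay, adding one oxygen to the group at this position still matters: trifluoromethoxy in place of trifluoromethyl gives a 2.5-fold higher number from compound 3 to compound 4 (0.40 log units; beyond the scatter), so sharing three fluorines does not make the two groups interchangeable here. Trifluoromethoxy nevertheless keeps much of the gain over methyl, with a 16-fold lower number from compound 1 to compound 4 (1.21 log units; beyond the scatter). Nothing available explains the difference between these groups.

Open is where a chlorine atom or a methoxy group at this position would fall among these numbers. Also open, on these data alone, is whether the trifluoromethoxy result holds with piperidin-1-yl in place of 4-methylpiperazin-1-yl on the chain.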